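A few compounds are considered here, and "the series" means these few. Any claim that something is new, unique, unknown or untested is made for them only; others in the source may bear on it.

Measured compounds:
- compound 1, `Cc1cc(C)c(NC(=O)N(Cc2ccc(-c3n[nH]c(C)n3)cc2)C2CCCCCC2)c(C)c1`: 120 nM
- compound 2, `CSc1cc(C)nc(SC)c1NC(=O)N(Cc1ccccc1)Cc1ccc(-c2cc[nH]n2)cc1`: 55 nM

In an assay on microsomes from intestine for inhibition of acyl-CoA:cholesterol acyltransferase (Oryctolagus cuniculus) (a lower number here means a stronger inhibitor, a higher number a weaker inhibitor), compound 1 gives 120 nM and stands as the higher of the two numbers; in this assay compound 2 gives 55 nM, and the gap between compound 1 and compound 2 lies beyond the scatter. Compound 2 differs from compound 1 in several places at once, so nothing is singled out by that pair.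

Compound 3, `Cc1cc(C)c(NC(=O)N(Cc2ccc(-c3ccccn3)cc2)C2CCCCCC2)c(C)c1`, is the next compound in the series and has not yet been measured in this assay. It differs from compound 1 in one place only: pyridin-2-yl in place of 5-methyl-1H-1,2,4-triazol-3-yl on an aromatic carbon. The shared core of compound 1 and the cycloheptyl group on the urea nitrogen are kept. For the measured compounds named here, no measured pair in the set isolates this change, so the expected size of the step is uncertain. The step from compound 1 to compound 3 is estimated as a 1.3-fold higher number from compound 1 to compound 3 (0.10 log units; within the scatter), within the scatter in either direction. For compound 3 the estimate in this assay is 150 nM, with a range from 50 nM to 500 nM.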

Compound 3, half-maximal inhibitory concentration: 33 nM
The estimate for compound 3 lay 4.5-fold (0.66 log units) above the measured number; measured number below the stated range.
By their numbers in this assay, from the lowest: compounds 3 and 2 (each within the scatter of the next); then compound 1.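

In this assay, for the compounds shown here, the group on an aromatic carbon para to a large group does affect inhibition: pyridin-2-yl in place of 5-methyl-1H-1,2,4-triazol-3-yl gives a 3.6-fold lower number from compound 1 to compound 3 (0.56 log units; beyond the scatter), the first change that can be read at a single place. Both groups have 6 heavy atoms, so the step comes without a change in that count, and the hydrogen-bond donor of the triazole is not needed at this place for compound 3 to reach 33 nM. Nothing measured here explains the step, and this one pair cannot separate the loss of the donor from the change in ring size, the change in hetero atoms or the loss of the methyl group.

Still open, going by these compounds, is whether the ring nitrogen matters, which a plain phenyl or a pyridin-3-yl group at this place would test, and whether a non-aromatic group such as morpholine or a carboxylic acid is tolerated there. Also open, on these data alone, is whether the step holds when a group other than cycloheptyl sits on the urea nitrogen.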